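The compounds below may be only part of what the source reports. "The series", "measured", "known", "first", "only" and "open" are said of these compounds alone.

Measured compounds:
compound 1, `CSc1nc(N)c2nc(O)n(Cc3ccccc3)c2n1`, 0.1 uM
compound 2, `Nc1ncnc2c1nc(O)n2Cc1ccc(F)cc1`, 10 uM
compound 3, `COc1nc2c(N)ncnc2n1Cc1ccccc1`, > 10 uM

In a functional assay (spleen, spleen) for activation, with Mus musculus as the target (a lower number here means that less compound is needed, a higher number that more compound is needed for the effect), compound 1 gives 0.1 uM. Compound 2 gives 10 uM in this assay. For compound 3 this assay returns only a limit, > 10 uM, so compound 3 has no number of its own and stands at the edge of what the assay reports; this is the limit described by the limit of > 10 uM in this assay, at which 1 of the 3 values shown sits. Compounds 1 and 2 both carry the hydroxy on the shared core and both give numbers; compound 3 carries a methoxy in that place and gives none.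

Compound 4, `Nc1ncnc2c1nc(O)n2Cc1ccccc1`, has not yet been measured in this assay. It differs from compound 3 by hydrogen in place of methyl on an oxygen on an aromatic ring. Compound 4 thus shares the hydroxy of compounds 1 and 2 and the benzyl of compounds 1 and 3. For the measured compounds named here, no measured step runs between compound 3 and compound 4, and with compound 3 at a limit the true size of the step cannot be fixed. The expected step from compound 3 to compound 4 is an at least 2.5-fold lower number from compound 3 to compound 4 (0.39 log units; beyond the scatter), toward less compound needed, and it is expected to exceed the usual scatter. Compound 4 is expected to give about 4 uM in this assay, within a range from 1 uM to 20 uM.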

Compound 4, minimum effective concentration: 10 uM
For compound 4 the middle estimate is 2.5-fold (0.40 log units) below the measured one, and the stated range covers the measured number.
By their numbers in this assay, from the lowest: compound 1; then compounds 2 and 4 (each within the scatter of the next).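

With compound 4 in hand, each earlier compound sits one change away from it in this assay, and hydrogen in place of fluoro on an aromatic carbon gives no change at the digits printed from compound 2 to compound 4 (within the scatter). For the compounds shown here, the methylsulfanyl on an aromatic carbon is the one change here with a readable effect, and it is a large one: a 100-fold higher number from compound 1 to compound 4 (2.00 log units; beyond the scatter). The methoxy to hydroxy step gives a number no higher from compound 3 to compound 4 (the limit leaves the size open). Compound 3 stands only at a limit: the limit of > 10 uM in this assay, at which 1 of the 4 values shown sits.

The compounds shown leave open whether the sulfur of the methylsulfanyl matters or whether an amine or a longer chain on that aromatic carbon would shift the number in the same way. Also open, from the compounds shown here alone, are the true size of the methoxy to hydroxy step and whether the hydroxy counts for as much on a compound that carries the methylsulfanyl.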